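A few compounds are considered here, and "the series" means these few. Any claim that something is new, unique, unknown or untested is made for them only; others in the source may bear on it.

Measured so far in a functional assay on OVCAR-8 cells (Homo sapiens); on this read-out lower numbers stand for stronger inhibition of growth and higher numbers for weaker inhibition of growth:

Compound 1 `O=S(=O)(/C=C/c1ccccc1)Cc1ccc(Nc2ncnc3ccccc23)cc1`: > 100000 nM (a limit)
Compound 2 `N#Cc1ccc(/C=C/S(=O)(=O)Cc2ccc(Nc3ncnc4ccccc34)cc2)cc1`: > 100000 nM (a limit)
Compound 3 `CC(C)(C)c1cc(/C=C/S(=O)(=O)Cc2ccc(Nc3ncnc4ccccc34)cc2)cc(C(C)(C)C)c1O`: 5000 nM (a number)

Compound 2 stands at the limit of > 100000 nM in this assay, at which 2 of the 3 values shown sit, and so has no number on this read-out, only a limit.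

The next change leads to compound 4 `O=S(=O)(/C=C/c1ccc(Cl)cc1)Cc1ccc(Nc2ncnc3ccccc23)cc1`, which carries chloro in place of cyano on an aromatic carbon, para to a large group, so that 4-cyanophenyl becomes 4-chlorophenyl: chloro in place of cyano on an aromatic carbon.

Among the measured compounds shown here, the one measured step on this aromatic carbon is a step that the two limits leave unreadable from compound 1 to compound 2, and it gives no size to carry over. Neither hydrogen nor cyano at this place gave a number. For the measured compounds named here, compound 3 at 5000 nM goes against that picture as the only number in the set, but it differs from compound 1 in more than one place, so it offers no measured step for this change.

Chloro is therefore expected to give no readable shift in this assay, and no direction can be assigned. The estimated step, a number no higher from compound 2 to compound 4 (the limit leaves the size open), is expected to stay within the scatter. For compound 4 the expected value is 100000 nM, with an estimated range from 20000 nM to 200000 nM, and a report of only a limit is the likeliest outcome.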

Compound 4, concentration for 50% growth inhibition: > 100000 nM
Compound 4 ended at the assay's limit; the forecaster's own chance of this, stated with the estimate: 75%; the middle value sits exactly at the limit.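

In this assay compound 4 gives > 100000 nM, which is a limit and not a number. No new step can be read among compound 1, compound 2 and compound 4, as all three sit at the same limit: the limit of > 100000 nM in this assay, at which 3 of the 4 values shown sit.

The compounds shown leave open whether hydrogen, cyano and chloro on this aromatic carbon differ at all in this assay.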